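The compounds below may be only part of what the source reports. "The series", "measured", "known", "first", "only" and "open" are said of these compounds alone.

Measured so far:
compound 1 `c1ccc2c(c1)ccn2-c1nc(N2CCCCC2)nc2ccccc12`: 50 ug/mL
compound 2 `Cn1cc(-c2nc(N3CCNCC3)nc3ccccc23)c2ccccc21`: 50 ug/mL
compound 3 `CN1CCN(c2nc(-n3ccc4ccccc43)c3ccccc3n2)CC1`: 11.5 ug/mL

In a functional assay on C-33-A cells (Homo sapiens) for antiproliferative activity, read by MTT assay (a higher number here means a weaker inhibitor, a lower number a stronger inhibitor), compound 3 gives the lowest of the three numbers; compound 1 and compound 2 both sit higher, each beyond the scatter. Among the measured compounds shown here, the only single-place step measured is a 4.3-fold lower number from compound 1 to compound 3 (0.64 log units; beyond the scatter), a modest change. Compound 4 `c1ccc(N2CCN(c3nc(-n4ccc5ccccc54)c4ccccc4n3)CC2)nc1` differs from compound 3 by pyridin-2-yl in place of methyl on an amine nitrogen in a ring. For the measured compounds named here, no measured step alters the group on the amine nitrogen of the six-membered non-aromatic ring with 2 nitrogen, so nothing bears directly on this change; the one step available concerns the ring itself, not what it carries. The expected step is therefore none beyond the scatter, with a 1.0-fold higher number from compound 3 to compound 4 (0.02 log units; within the scatter) as the working guess. For compound 4 the estimate is 12 ug/mL, within 5 ug/mL to 30 ug/mL.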

Compound 4, half-maximal inhibitory concentration: 50 ug/mL
Compound 4: middle estimate off by 4.2-fold (0.62 log units), on the low side, outside the stated range (above it).
By their numbers in this assay, from the lowest: compound 3; then compounds 1, 2 and 4 (each within the scatter of the next).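

In this assay, the group on the amine nitrogen of the six-membered non-aromatic ring is not a silent position: pyridin-2-yl in place of methyl gives a 4.3-fold higher number from compound 3 to compound 4 (0.64 log units; beyond the scatter). The lower number of compound 3 therefore depends on what this nitrogen carries, not on the ring alone. No measurement available here accounts for this step. On these data alone, whether ethyl or acetyl on this nitrogen would retain the number of compound 3 remains open. Also open, as far as these compounds go, is whether a phenyl ring would match pyridin-2-yl.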